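A Chlorophenyl Swap on a Weak Starting Compound

The source may report more compounds than this note shows. Statements on the series, on what has been measured and on what is new or still open speak of the compounds shown alone.

Compound 1 `CCOc1ccc(Br)cc1-c1cc(Nc2cccc(C#N)c2)nc(N)n1` - > 1000 nM
Compound 2 `Nc1nc(Nc2ccc(Cl)cc2)cc(-c2cc(Cl)ccc2Cl)n1` - 190 nM

In a functional assay on DU-145 cells (Homo sapiens) for inhibition (on this read-out higher numbers stand for weaker inhibition and lower numbers for stronger inhibition), compound 1 stands at > 1000 nM, which is a limit of the assay and not a number. Compound 2 gives 190 nM in this assay as a true number.

Compound 3 `CCOc1ccc(Br)cc1-c1cc(Nc2ccc(Cl)cc2)nc(N)n1` has not yet been measured. It keeps the core of compound 1 and changes one group (4-chlorophenyl in place of 3-cyanophenyl on a nitrogen on an aromatic ring). Going by the values given here, the incoming 4-chlorophenyl on a nitrogen on an aromatic ring is also carried by compound 2, whose 190 nM is the only number available for that group. Among the compounds with values here, no measured pair shows this change on its own, so that number is only a loose guide.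

The step expected is an at least 2.5-fold lower number from compound 1 to compound 3 (0.39 log units; beyond the scatter), towards stronger inhibition, and its estimated size stays uncertain while the starting point is only a limit. In this assay the estimate for compound 3 is 400 nM, expected to fall between 120 nM and 1500 nM for most measurements.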

Compound 3, half-maximal inhibitory concentration: 80 nM
For compound 3 the middle estimate is 5.0-fold (0.70 log units) above the measured one, outside the stated range (below it).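

Going by these compounds alone, replacing 3-cyanophenyl with 4-chlorophenyl on a nitrogen on an aromatic ring, with the rest of the structure kept, gives the first direct reading of this position in this assay: an at least 12-fold lower number from compound 1 to compound 3 (1.09 log units; beyond the scatter). Compound 1 gives > 1000 nM, which is a limit of the assay and not a number. The step is therefore a minimum and its full size cannot be read, because its starting point is a limit: the limit of > 1000 nM in this assay, at which 1 of the 3 values shown sits.

The compounds shown leave open whether the change in inhibition follows from gaining the chlorine, from losing the nitrile, or from where the group sits on the phenyl ring, as this single exchange alters all of these at once. Plain phenyl, 3-chlorophenyl or 4-cyanophenyl on the same nitrogen would be needed to tell these apart, and it also remains open how far the exchange would carry over to compounds with a different group in place of the bromo-ethoxyphenyl part of compound 3.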